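A few compounds are considered here, and "the series" means these few. Any claim that something is new, unique, unknown or untested is made for them only; others in the source may bear on it.

Measured so far:
compound 1, `Nc1ccc(CN2CCN(c3ccc(N4C[C@H](Cn5ccnn5)OC4=O)cc3F)CC2)cc1`: 2660 nM
compound 2, `O=C1O[C@@H](Cn2ccnn2)CN1c1ccc(N2CCN(Cc3ccc([N+](=O)[O-])o3)CC2)c(F)c1`: 11500 nM

In an in vivo ADME assay on the whole organism (strain Sprague-Dawley) for pharmacokinetics, with Rattus norvegicus as the target, at a dose of 10 mg/kg by the oral route (on this read-out higher numbers stand for higher exposure at the dose given and lower numbers for lower exposure), compound 2 gives 11500 nM, the highest of the two numbers. The nearest is compound 1, which in this assay gives 2660 nM; the step between them, a 4.3-fold higher number from compound 1 to compound 2 (0.64 log units; beyond the scatter), lies beyond the scatter. Compound 3, `O=C1O[C@@H](Cn2ccnn2)CN1c1ccc(N2CCN(Cc3cccc([N+](=O)[O-])c3)CC2)c(F)c1`, has not yet been measured in this assay. It differs from compound 2 by 3-nitrophenyl in place of 5-nitrofuran-2-yl on a saturated chain carbon bound to an amine nitrogen in a ring. Among the compounds with values here, only one measured step touches that place on the molecule, a 4.3-fold higher number from compound 1 to compound 2 (0.64 log units; beyond the scatter), where 5-nitrofuran-2-yl took the place of 4-aminophenyl. Within the data shown here, the move from compound 2 to compound 3 returns to a six-membered aromatic ring of carbon only but keeps the nitro group, so that single step points to no clear direction; the data give no second pair to test it. The author therefore expects a step of no more than modest size, if any beyond the scatter, with a slight lean downward, a 1.8-fold lower number from compound 2 to compound 3 (0.25 log units; within the scatter). Compound 3 is expected to give 6500 nM in this assay, within a range of 2200 nM to 19000 nM.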

Compound 3, maximal plasma concentration: 6730 nM
Compound 3: middle estimate off by 1.0-fold (0.02 log units), on the low side, within the range that was stated.
By their numbers in this assay, from the lowest: compound 1; then compounds 3 and 2 (each within the scatter of the next).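

In this assay, the exchange of 5-nitrofuran-2-yl for 3-nitrophenyl on the saturated chain carbon bound to an amine nitrogen in a ring gives a 1.7-fold lower number from compound 2 to compound 3 (0.23 log units; within the scatter) and so leaves compound 2 and compound 3 within the scatter of each other, which shows that at this position the five-membered aromatic ring with its hetero atom can give way to a six-membered aromatic ring of carbon only without a readable change. The gap seen earlier with the 4-aminophenyl group now has a second instance, a 2.5-fold higher number from compound 1 to compound 3 (0.40 log units; beyond the scatter) being beyond the scatter and modest, so both nitro-bearing groups stand above compound 1 and none of the three compounds goes against this, although the pattern rests on that single 4-aminophenyl compound. Nothing available explains either step.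

Still open, from the compounds shown here alone, is how a plain phenyl or an unsubstituted furan-2-yl at this position would compare with these three compounds, which would show whether the nitro group goes with the higher numbers. Also open, going by these compounds, is whether 4-nitrophenyl would stand with compound 3 or nearer compound 1, since the step from compound 1 to compound 3 changes both the group and where it sits on the ring.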